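A few compounds are considered here, and "the series" means these few. Any claim that something is new, unique, unknown or untested is made for them only; others in the source may bear on it.

Measured compounds in a functional assay on PC-3 cells (Homo sapiens) for inhibition, read by MTT assay, with a stated time of 72 h; on this read-out lower numbers stand for stronger inhibition and higher numbers for weaker inhibition:
compound 1 `C=CC(=O)Nc1cccc(NC(=O)CSc2nc(Nc3ccccc3C)c3ccccc3n2)c1` gives 23200 nM;
compound 2 `C=CC(=O)Nc1cccc(NC(=O)CSc2nc(Nc3ccc(F)cc3)c3ccccc3n2)c1` gives 8240 nM;
compound 3 `C=CC(=O)Nc1cccc(NC(=O)CSc2nc(Nc3ccc(CC)cc3)c3ccccc3n2)c1` gives 24300 nM.

Compound 3 has the highest number of the three. Its nearest neighbour is compound 1, whose number is about the same, the gap being within the scatter; its furthest is compound 2, whose number is markedly lower, the gap being beyond the scatter. Among the measured steps, the change from compound 1 to compound 2 gave a 2.8-fold lower number from compound 1 to compound 2 (0.45 log units; beyond the scatter), the change from compound 1 to compound 3 gave a 1.0-fold higher number from compound 1 to compound 3 (0.02 log units; within the scatter), and the change from compound 2 to compound 3 gave a 2.9-fold higher number from compound 2 to compound 3 (0.47 log units; beyond the scatter).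

Compound 4 `C=CC(=O)Nc1cccc(NC(=O)CSc2nc(Nc3ccc(Cl)c(Cl)c3)c3ccccc3n2)c1` differs from compound 3 in that (3,4-dichlorophenyl in place of 4-ethylphenyl on a nitrogen on an aromatic ring). Among the measured compounds shown here, the step that bears on it most directly is the one between compound 2 and compound 3, which exchanged a halogen for an ethyl group on that aromatic carbon and gave a modest rise; the new compound puts halogens back on that ring, with one more than in compound 2. A modest fall in this assay is therefore expected. Compound 4 is estimated at 9000 nM, within a range of 3000 nM to 27000 nM, which corresponds to an expected step of a 2.7-fold lower number from compound 3 to compound 4 (0.43 log units; beyond the scatter).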

Compound 4, half-maximal inhibitory concentration: 27600 nM
The estimate for compound 4 lay 3.1-fold (0.49 log units) below the measured number, outside the stated range (above it).
By their numbers in this assay, from the lowest: compound 2; then compounds 1, 3 and 4 (each within the scatter of the next).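

In this assay, putting 3,4-dichlorophenyl in place of 4-ethylphenyl on the nitrogen gave a 1.1-fold higher number from compound 3 to compound 4 (0.06 log units; within the scatter) and, measured against the 2-methylphenyl compound, a 1.2-fold higher number from compound 1 to compound 4 (0.08 log units; within the scatter), so these three aryl groups stand level even though they differ in what they carry on the ring. Halogen on this ring therefore does not by itself go with a lower number: compound 2 fits such a reading and compound 4 goes against it, with a 3.3-fold higher number from compound 2 to compound 4 (0.52 log units; beyond the scatter) leaving compound 2 the strongest of the four, beyond the scatter of each of the others. Nothing available on these compounds accounts for this difference between the two halogenated rings.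

The compounds shown leave open whether the lower number of compound 2 belongs to fluoro itself or to the ring carrying a single halogen, a question that a ring with a single chlorine would help to settle. They also leave open how a methoxy group or an amine on this ring would read in this assay, and whether any group here can reach a number clearly lower than that of compound 2 at 8240 nM.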